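Cytotoxicity of a Tert-Butyl Amide Analogue

The compounds below may be only part of what the source reports. "The series", "measured", "known", "first", "only" and "open" are said of these compounds alone.

Compound 1 `COc1ccc(CNC(=O)c2c(NC(=O)C(F)(F)F)sc3c2CCCCC3)cc1` was examined in an ADME assay on THP-1 cells (Homo sapiens) for cytotoxicity; on this read-out higher numbers stand for lower toxicity in this test and lower numbers for higher toxicity in this test. In this assay compound 1 gives > 50000 nM, which is a limit of the test rather than a measured number. Two other compounds from the same series share that outcome. Compound 2 `COc1ccc(NC(=O)c2c(NC(=O)c3ccccc3)sc3c2CCCCC3)cc1` returns > 50000 nM in this assay, again a limit. Compound 3 `COc1ccc(NC(=O)c2c(NC(=O)C(F)(F)F)sc(C)c2C)cc1` likewise shows > 50000 nM in this assay, also a limit. Compound 1 therefore stands exactly where everything measured here stands: the limit of > 50000 nM in this assay, at which 3 of the 3 values shown sit. No pair among these three compounds differs in only one place, so no step between measured compounds can be sized from these data.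

Compound 4 `CC(C)(C)NC(=O)c1c(NC(=O)C(F)(F)F)sc2c1CCCCC2` has not yet been measured in this assay. It differs from compound 1 in one respect: tert-butyl in place of 4-methoxybenzyl on an amide-type nitrogen. With all three measured compounds sitting at the limit, nothing among them points to a step beyond the usual scatter in either direction, and the expected step that the limit leaves unreadable from compound 1 to compound 4 is essentially none. Compound 4 is accordingly expected to give about 80000 nM in this assay, within a range of 30000 nM to 200000 nM, and most probably to be reported only as a limit once more.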

Compound 4, half-maximal cytotoxic concentration: > 50000 nM
Compound 4 ended at the assay's limit; the forecaster's own chance of this, stated with the estimate: 85%; the middle value is on the limit's open side.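

In this assay compound 1 and compound 4 both end at a limit, so no step can be read for tert-butyl in place of 4-methoxybenzyl. The compounds shown leave open at what concentration, if any, each becomes cytotoxic to these cells, and whether any change among them alters that concentration.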